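This account rests on a few compounds, and the source may have more. Where it says the series, first, only, none or still open, it means among the compounds named here.

In a functional assay on NCI-H460 cells (Homo sapiens) for inhibition, read by MTT assay, with a stated time of 4 days (a higher number here means a weaker inhibitor, a lower number a stronger inhibitor), compound 1 `COc1ccc(C(=NNC(=O)NNC(=O)NCCCC(C)Nc2cc(OC)cc3cccnc23)c2ccc(OC)cc2)cc1` gives 5000 nM, and compound 3 `COc1cc(NC(C)CCCNC(=O)Nc2ccc(Cl)c(C(F)(F)F)c2)c2ncccc2c1` gives 28000 nM. Compound 2 `COc1cc(NC(C)CCCNC(=O)NNC(=O)N(CCO)CCO)c2ncccc2c1` gives only a limit of the assay, > 100000 nM, so it sits at the limit of > 100000 nM in this assay, at which 1 of the 3 values shown sits, rather than at a number. Compound 4 `COc1cc(NC(C)CCCNC(=O)NNC(=O)Nc2ccc(Cl)c(C(F)(F)F)c2)c2ncccc2c1` is compound 2 with a single change: (4-chloro-3-(trifluoromethyl)phenyl)amino in place of bis(2-hydroxyethyl)amino on a carbonyl carbon. Going by the values given here, one measured step bears on this change: an at least 3.5-fold lower number from compound 2 to compound 3 (0.55 log units; beyond the scatter), which brought in the same group in place of the bis(2-hydroxyethyl)carbamoyl)amino part. A drop of comparable size, towards a stronger inhibitor, is therefore expected for compound 4 in this assay. Compound 4 is estimated at 30000 nM, with a range from 8000 nM to 100000 nM. That estimate means an expected step of an at least 3.3-fold lower number from compound 2 to compound 4 (0.52 log units; beyond the scatter).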

Compound 4, half-maximal inhibitory concentration: 13000 nM
Estimate against measurement, compound 4: 2.3-fold (0.36 log units) above; measured number inside the range.
By their numbers in this assay, from the lowest: compound 1; then compound 4; then compound 3. At a limit, above all of these: compound 2.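

In this assay, putting (4-chloro-3-(trifluoromethyl)phenyl)amino on the carbonyl carbon gives an at least 7.6-fold lower number from compound 2 to compound 4 (0.88 log units; beyond the scatter). The gain seen earlier with this substituted phenyl group therefore also appears when only bis(2-hydroxyethyl)amino leaves and the rest of compound 2 stays in place. Compound 2 has a limit of the assay rather than a number, so the full size of this step stays unknown: the limit of > 100000 nM in this assay, at which 1 of the 4 values shown sits.

The compounds shown leave open whether the chlorine, the trifluoromethyl or the ring itself carries the drop. A plain phenylamino or a 4-chlorophenylamino group on this carbonyl carbon would help separate them.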